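Pyrimidinyl amide replacing methoxyphenyl amide in a thiophene series

The source may report more compounds than this note shows. Statements on the series, on what has been measured and on what is new or still open speak of the compounds shown alone.

Of the compounds shown here, three with a shared core have been measured in a functional assay on HL-60 cells (Homo sapiens) for antiproliferative activity, with a stated time of 24 h; on this read-out lower numbers stand for stronger inhibition and higher numbers for weaker inhibition. Compound 1 `NC(=O)c1c(NC(=O)c2ccccc2Cl)sc2c1CCN(C(=O)Nc1c(Cl)cccc1Cl)C2` gives 17700 nM. Compound 2 `NC(=O)c1c(NC(=O)c2ccccc2I)sc2c1CCN(C(=S)Nc1ccccc1Cl)C2` gives 8560 nM. Compound 3 `COc1ccccc1C(=O)Nc1sc2c(c1C(N)=O)CCN(C(=S)Nc1ccccc1Cl)C2` gives 20800 nM, the highest of the three numbers; its gap to compound 1 lies within the scatter, while the step of a 2.4-fold higher number from compound 2 to compound 3 (0.39 log units; beyond the scatter) is a modest one beyond it.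

Compound 4 `NC(=O)c1c(NC(=O)c2ccncn2)sc2c1CCN(C(=S)Nc1ccccc1Cl)C2` differs from compound 3 by pyrimidin-4-yl in place of 2-methoxyphenyl on a carbonyl carbon. Going by the values given here, the only measured step, from compound 2 to compound 3, concerns a change within the aryl group that is now replaced altogether, so no measured step bears directly on exchanging the whole ring for a pyrimidin-4-yl. Without such a comparison, the step in this assay cannot be expected to exceed the scatter in either direction. The expected step is a 1.0-fold lower number from compound 3 to compound 4 (0.02 log units; within the scatter), within the scatter. Compound 4 is therefore estimated at 20000 nM, with a range from 6000 nM to 60000 nM.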

Compound 4, half-maximal inhibitory concentration: 34600 nM
Estimate against measurement, compound 4: 1.7-fold (0.24 log units) below; low and high end bracket the measured number.
By their numbers in this assay, from the lowest: compound 2; then compounds 1, 3 and 4 (each within the scatter of the next).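

In this assay, exchanging the whole 2-methoxyphenyl for pyrimidin-4-yl on this carbonyl carbon gives a 1.7-fold higher number from compound 3 to compound 4 (0.22 log units; within the scatter), so an aromatic ring with hetero atoms at this place cannot be told apart from the 2-methoxyphenyl ring in this read-out. Set against the 2-iodophenyl group, the same ring gives a 4.0-fold higher number from compound 2 to compound 4 (0.61 log units; beyond the scatter), a modest step, so compound 2 stands apart from both compound 3 and compound 4, while those two stay together. Nothing given here accounts for these differences.

From the compounds shown here alone, whether a morpholine ring or a simple alkyl chain on this carbonyl carbon would keep the number in the same range remains open. Going by these compounds, it is also open whether pyrimidin-4-yl would give a similar step on the remainder of compound 1.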